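This account rests on a few compounds, and the source may have more. Where it says the series, first, only, none or still open, it means among the compounds named here.

Working notes on the series.

Three compounds have been run so far in a functional assay on M21 cells (Homo sapiens) for antiproliferative activity, read by sulforhodamine B assay, with a stated time of 48 h; on this read-out lower numbers stand for stronger inhibition of growth and higher numbers for weaker inhibition of growth. Compound 1 `CCOC(=O)c1ccc(-c2cc(N3CCC(CNS(N)(=O)=O)CC3)ncn2)cc1` gives 5000 nM. Compound 3 `CCOC(=O)c1ccc(-c2cc(N3CCC(CCNS(N)(=O)=O)CC3)ncn2)cc1` differs from compound 1 by (sulfamoylamino)methyl in place of sulfamoylamino on a saturated chain carbon bound to a saturated ring carbon, and in this assay compound 3 gives 9000 nM; the step is a 1.8-fold higher number from compound 1 to compound 3 (0.26 log units; within the scatter). Compound 2 `NS(=O)(=O)NCC1CCN(c2cc(-c3cccc4ccccc34)ncn2)CC1` carries a different core; the difference between the core of compound 2 and the core of compound 1 is not broken down here. In this assay compound 2 gives 6600 nM, and its values against compound 1 and compound 3 stay within the scatter, so no order among the three is drawn.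

Compound 4 `NS(=O)(=O)NCCC1CCN(c2cc(-c3cccc4ccccc34)ncn2)CC1` has not been measured. It differs from compound 2 by (sulfamoylamino)methyl in place of sulfamoylamino on a saturated chain carbon bound to a saturated ring carbon, the same change and at the same place as from compound 1 to compound 3. Within the data shown here, only that one earlier instance is available, and it stayed within the scatter, so the step from compound 2 to compound 4 is expected to be modest, near a 1.5-fold higher number from compound 2 to compound 4 (0.18 log units; within the scatter), resting on a 1.8-fold higher number from compound 1 to compound 3 (0.26 log units; within the scatter). Compound 4 is therefore estimated at 10000 nM in this assay, with a range from 5000 nM to 22000 nM.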

Compound 4, concentration for 50% growth inhibition: 1800 nM
Estimate against measurement, compound 4: 5.6-fold (0.74 log units) above; the measured number lies below the stated range.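

Carried to the core of compound 2, the change from (sulfamoylamino)methyl to 2-(sulfamoylamino)ethyl gives a 3.7-fold lower number from compound 2 to compound 4 (0.56 log units; beyond the scatter) in this assay. The change therefore does not carry over with the same result from one core to the other: the same change on two cores in this assay, a 1.8-fold higher number (0.26 log units; within the scatter) from compound 1 to compound 3 and a 3.7-fold lower number (0.56 log units; beyond the scatter) from compound 2 to compound 4, 6.6-fold (0.82 log units) apart, beyond the scatter of two such steps

Among these compounds, this shows that, for these two pairs, the result of the chain change depends on the core it sits on, but with only one pair per core it gives no rule for any further core and does not show which feature of the two cores sets the difference.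

Going by these compounds, it remains open whether a longer chain in the same place would extend the result seen on the core of compound 2, and how such a chain would read out on the core of compound 1. On these data alone, it is also open whether an amine or a carboxylic acid at the chain end, in place of the sulfamoylamino group, would show the same dependence on the core.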